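The compounds below may be only part of what the source reports. "The series", "measured", "known", "first", "only" and "open" are said of these compounds alone.

Compound 3 `CC(C)Cn1c(=O)[nH]c2nc(-c3cnn(Cc4cccc(F)c4)c3)[nH]c2c1=O` sits in the middle of the three values in hand: in an assay on HEK293 cells for displacement of a labelled ligand from adenosine receptor A2b (Homo sapiens) (a higher number here means a weaker inhibitor, a lower number a stronger inhibitor), compound 3 gives 24 nM, the second highest of the three numbers. Nearest to it is compound 2 `CCCCn1c(=O)[nH]c2nc(-c3cnn(Cc4cccc(C(F)(F)F)c4)c3)[nH]c2c1=O`, which in this assay gives 30 nM, a gap within the scatter. Furthest from it is compound 1 `CCCn1c(=O)[nH]c2nc(-c3cnn(Cc4cccc(F)c4)c3)[nH]c2c1=O`, which in this assay gives 11 nM; the only single-point step in the set, a 2.2-fold higher number from compound 1 to compound 3 (0.34 log units; beyond the scatter), separates these two. Compound 4 `CC(C)Cn1c(=O)[nH]c2nc(-c3cnn(Cc4cccc(C(F)(F)F)c4)c3)[nH]c2c1=O` differs from compound 3 by trifluoromethyl in place of fluoro on an aromatic carbon. No measured step isolates this change: compound 1 and compound 2 carry fluoro and trifluoromethyl on that ring but also differ in the chain, so their values show only that the trifluoromethyl partner reads higher, and the one listed step concerns the chain, not the ring. A modest rise, or none beyond the scatter, is therefore expected, and compound 4 is estimated at 40 nM with a range from 15 nM to 110 nM, a step of a 1.7-fold higher number from compound 3 to compound 4 (0.22 log units; within the scatter) that is expected rather than measured.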

Compound 4, inhibition constant: 28 nM
Estimate against measurement, compound 4: 1.4-fold (0.15 log units) above; the range from low to high includes it.
By their numbers in this assay, from the lowest: compound 1; then compounds 3, 4 and 2 (each within the scatter of the next).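

Read on its own for the first time in this assay, the exchange on the aromatic carbon gives a 1.2-fold higher number from compound 3 to compound 4 (0.07 log units; within the scatter), so 3-fluorophenyl and 3-(trifluoromethyl)phenyl cannot be told apart when the chain of compound 3 is in place, despite the added heavy atoms. With trifluoromethyl held constant, the chain change gives a 1.1-fold lower number from compound 2 to compound 4 (0.03 log units; within the scatter), so isopropyl in place of propyl on the saturated chain carbon bound to an aromatic nitrogen makes no difference beyond the scatter in this pair. Nothing measured here bears on the reason for either result.

The compounds shown leave open whether the ring exchange would read the same with the shorter chain of compound 1. They also leave open how a nitrile or a methoxy group on that aromatic carbon, or a longer chain on the aromatic nitrogen, would read.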